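A few compounds are considered here, and "the series" means these few. Any claim that something is new, unique, unknown or untested is made for them only; others in the source may bear on it.

Measured compounds:
- compound 1, `COc1ccc(OC)c(/C=C/c2nnc(Nc3ccc(Cl)cc3)o2)c1`: > 100000 nM in a functional assay on HCT-15 cells (Homo sapiens) for antiproliferative activity, read by sulforhodamine B assay, with a stated time of 48 h; on this read-out lower numbers stand for higher toxicity in this test and higher numbers for lower toxicity in this test
- compound 2, `COc1ccc(OC)c(/C=C/C(=O)N/N=C/c2ccc(Cl)cc2)c1`: > 100000 nM

In this assay compound 2 reaches only the limit of > 100000 nM, which is a limit of the test and not a measured number. Compound 1 likewise stops at its own limit, > 100000 nM. Both values sit at the limit of > 100000 nM in this assay, at which 2 of the 2 values shown sit, so no value beyond the scatter separates them. Compound 3, `COc1ccc(OC)c(/C=C/C(=O)N/N=C/c2ccccc2)c1`, differs from compound 2 by hydrogen in place of chloro on an aromatic carbon. With both neighbours at the limit, no clear shift is expected from compound 2 to compound 3 in this assay, the step that the limit leaves unreadable from compound 2 to compound 3 being an expectation only. Compound 3 is estimated at 150000 nM, between 40000 nM and 500000 nM.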

Compound 3, concentration lethal to 50% of the cells: > 100000 nM
Compound 3 ended at the assay's limit (the forecaster's own chance of this, stated with the estimate: 85%); the middle value does not contradict the limit.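

Compound 2 and compound 3 both stop at a limit of the test, so replacing chloro with hydrogen gives no readable step: the limit of > 100000 nM in this assay, at which 3 of the 3 values shown sit. As far as these compounds go, whether that replacement changes toxicity in this assay stays open.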